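Adding methylsulfonyl to the amino nitrogen of compound 3

The source may report more compounds than this note shows. Statements on the series, on what has been measured and on what is new or still open speak of the compounds shown alone.

Measured in a physicochemical assay for lipophilicity; on this read-out lower numbers stand for lower lipophilicity and higher numbers for higher lipophilicity:
compound 1 `CC(C)c1cc(Br)cc(C(C)C)c1O`: 5.49
compound 2 `CC(C)c1cc(I)cc(C(C)C)c1O`: 5.75
compound 3 `CC(C)c1cc(N)cc(C(C)C)c1O`: 3.1

Compound 3 stands lowest of the three in this assay. Iodo in place of bromo gave a number 0.26 log units higher from compound 1 to compound 2 (within the scatter). Amino gave a number 2.39 log units lower from compound 1 to compound 3 (beyond the scatter) in place of bromo and a number 2.65 log units lower from compound 2 to compound 3 (beyond the scatter) in place of iodo. Both amino steps are large, but each exchanges a whole group on an aromatic carbon. Within the data shown here, no measured step alters the nitrogen, so they bear on compound 4 `CC(C)c1cc(NS(C)(=O)=O)cc(C(C)C)c1O` only indirectly. It carries methylsulfonyl in place of hydrogen on a nitrogen on an aromatic ring. Only a small upward step, not beyond the scatter, is expected in this assay. The estimated step is a number 0.20 log units higher from compound 3 to compound 4 (within the scatter). Compound 4 is estimated at 3.3, with an expected range from 2.7 to 3.9.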

Compound 4, partition coefficient: 3.14
Compound 4: middle estimate off by 0.16 log units, on the high side; measured number inside the range.
By their numbers in this assay, from the lowest: compounds 3 and 4 (each within the scatter of the next); then compounds 1 and 2 (each within the scatter of the next).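

In this assay methylsulfonyl on the nitrogen gives a number 0.04 log units higher from compound 3 to compound 4 (within the scatter) and so yields a number the read-out cannot separate from that of the free amino group. Methanesulfonamido on the aromatic carbon gives a number 2.61 log units lower from compound 2 to compound 4 (beyond the scatter) in place of iodo and a number 2.35 log units lower from compound 1 to compound 4 (beyond the scatter) in place of bromo and so leaves steps as large as those of amino. Nothing at hand offers a reason for these numbers.

On these data alone, whether ethylsulfonyl or acetyl on the same nitrogen would behave alike stays open, as does the effect of a methyl group there.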